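Swapping a Butyl for an Isopropyl on the Phenyl Ring

This account rests on a few compounds, and the source may have more. Where it says the series, first, only, none or still open, it means among the compounds named here.

Measured so far:
- Compound 1 `CCCCc1ccc(-c2cc(-c3cn([C@H]4C[C@H](OC(C)=O)[C@@H](COC(C)=O)O4)c(=O)[nH]c3=O)on2)cc1`: 71.4%
- Compound 2 `CC(=O)OC[C@H]1O[C@@H](n2cc(-c3cn(Cc4ccc(C(C)(C)C)cc4)nn3)c(=O)[nH]c2=O)C[C@@H]1OC(C)=O`: 94.2%
- Compound 3 `CC(C)(C)c1ccc(-c2cc(-c3cn([C@H]4C[C@H](O)[C@@H](CO)O4)c(=O)[nH]c3=O)on2)cc1`: 79.8%

In a functional assay on HCT-15 cells (Homo sapiens) for cytotoxicity, read by sulforhodamine B assay, tested at 10 uM (on this read-out lower numbers stand for less inhibition and higher numbers for more inhibition at the one concentration tested (going by the name of the read-out)), compound 1 gives the lowest of the three numbers. Compound 3 sits close to it, within the usual scatter, so the two cannot be told apart. Compound 2 lies beyond the scatter, clearly higher than compound 1.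

Compound 4 `CC(=O)OC[C@H]1O[C@@H](n2cc(-c3cc(-c4ccc(C(C)C)cc4)no3)c(=O)[nH]c2=O)C[C@@H]1OC(C)=O` has not been measured. It differs from compound 1 in one place: isopropyl in place of butyl on an aromatic carbon. For the measured compounds named here, no measured pair shows this change, so the step from compound 1 to compound 4 in this assay is unknown. The step of a number 1.6 percentage points higher from compound 1 to compound 4 (within the scatter) is expected to be small, within the scatter, with no clear direction.

Compound 4 is therefore expected to give 73%, in a range from 57% to 89%.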

Compound 4, a percentage reported as inhibition, at one concentration (the size of the read-out at that concentration, not a potency): 80.9%
Estimate against measurement, compound 4: 7.9 percentage points below; low and high end bracket the measured number.
By their numbers in this assay, from the lowest: compounds 1, 3 and 4 (each within the scatter of the next); then compound 2.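

In this assay, replacing butyl with isopropyl on the aromatic ring gives a number 9.5 percentage points higher from compound 1 to compound 4 (within the scatter). For the compounds shown here, this is the first direct reading at this position, and it shows that the two chains cannot be told apart here, so the 4-butylphenyl and 4-isopropylphenyl forms read alike in this comparison. No measurement offered explains this result.

Still open, as far as these compounds go, is whether a longer chain such as hexyl, or a group of another kind such as an amine or a carboxylic acid, would stand apart from butyl at this position.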